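Adding isopropyl to the hydroxyethyl chain of compound 3

The compounds below may be only part of what the source reports. "The series", "measured", "known", "first", "only" and "open" are said of these compounds alone.

Three compounds share one core and differ in a single place, the group on a saturated chain carbon two bonds along the chain from an amide-type nitrogen: compound 1 `CCn1c(C(=O)NCCC(=O)OC)ccc1C(CC)(CC)c1ccc(OCS(=O)(=O)c2ccccc2)c(C)c1`, compound 2 `CCN(CC)CCNC(=O)c1ccc(C(CC)(CC)c2ccc(OCS(=O)(=O)c3ccccc3)c(C)c2)n1CC` and compound 3 `CCn1c(C(=O)NCCO)ccc1C(CC)(CC)c1ccc(OCS(=O)(=O)c2ccccc2)c(C)c1`. All three were tested in a functional assay on MCF7 cells (Homo sapiens) for antiproliferative activity, read by MTT assay, with a stated time of 24 h; a higher number here means a weaker inhibitor, a lower number a stronger inhibitor. Compound 1 gives > 50000 nM, which is a limit of the assay and not a number. Compound 2 gives 4680 nM. Compound 3 gives 15500 nM, the higher of the two real numbers.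

Hydroxy in place of methoxycarbonyl gives an at least 3.2-fold lower number from compound 1 to compound 3 (0.50 log units; beyond the scatter), and hydroxy in place of diethylamino gives a 3.3-fold higher number from compound 2 to compound 3 (0.52 log units; beyond the scatter). Diethylamino in place of methoxycarbonyl gives an at least 10-fold lower number from compound 1 to compound 2 (1.02 log units; beyond the scatter).

Compound 4 `CCn1c(C(=O)N[C@H](CO)C(C)C)ccc1C(CC)(CC)c1ccc(OCS(=O)(=O)c2ccccc2)c(C)c1` keeps the hydroxy of compound 3 but changes the chain: isopropyl in place of hydrogen on a saturated chain carbon bound to an amide-type nitrogen and a saturated chain carbon. This is isopropyl in place of hydrogen on a saturated chain carbon bound to an amide-type nitrogen and a saturated chain carbon, so (2-hydroxyethyl)carbamoyl becomes (1-(hydroxymethyl)-2-methylpropyl)carbamoyl. The measured steps all swap the group at another carbon, so they show that this chain matters but not how this change will act. No step beyond the scatter is therefore expected in this assay, and the range must stay wide.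

For compound 4 the estimated value is 13000 nM, with an expected range from 4500 nM to 40000 nM. That estimate means an expected 1.2-fold lower number from compound 3 to compound 4 (0.08 log units; within the scatter).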

Compound 4, half-maximal inhibitory concentration: 25500 nM
Compound 4: middle estimate off by 2.0-fold (0.29 log units), on the low side; low and high end bracket the measured number.
By their numbers in this assay, from the lowest: compound 2; then compounds 3 and 4 (each within the scatter of the next). At a limit, above all of these: compound 1.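

In this assay, isopropyl in place of hydrogen on a saturated chain carbon bound to an amide-type nitrogen and a saturated chain carbon gives a 1.6-fold higher number from compound 3 to compound 4 (0.22 log units; within the scatter), so this added group produces no change that can be told apart from repeat measurements. The gap seen earlier between the hydroxy and diethylamino chains also appears with this second hydroxy chain: 1-(hydroxymethyl)-2-methylpropyl in place of 2-(diethylamino)ethyl on an amide-type nitrogen gives a 5.4-fold higher number from compound 2 to compound 4 (0.74 log units; beyond the scatter). The remaining step, an at least 1.9-fold lower number from compound 1 to compound 4 (0.29 log units; that floor lies within the scatter), starts from a value of compound 1 that is a limit and not a number, and it gives no firm order for this pair: the limit of > 50000 nM in this assay, at which 1 of the 4 values shown sits.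

The compounds shown leave open whether a diethylamino group on the branched chain of compound 4, in place of its hydroxy, would bring the number down as it does on the unbranched chain. Also open, as far as these compounds go, is how a methyl or a phenyl at the same carbon would act, and how the mirror-image arrangement at that carbon would compare with compound 4.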